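Removing the amino group from a purine-like chloride

The compounds below may be only part of what the source reports. "The series", "measured", "known", "first", "only" and "open" are said of these compounds alone.

Measured compounds:
compound 1 `Nc1nc(Cl)c2ncn(Cc3ccccc3CCl)c2n1` — > 100000 nM
compound 2 `ClCc1ccc(Cn2cnc3c(Cl)nc(Cl)nc32)cc1` — 66100 nM
compound 3 `ClCc1ccccc1Cn1cnc2ncnc(Cl)c21` — 5880 nM

Going by these compounds, in a functional assay on K562 cells (Homo sapiens) for cytotoxicity, read by sulforhodamine B assay, with a stated time of 48 h (on this read-out lower numbers stand for stronger inhibition of growth and higher numbers for weaker inhibition of growth), compound 1 gives > 100000 nM, which is a limit of the assay and not a number, so compound 1 sits at the limit of > 100000 nM in this assay, at which 1 of the 3 values shown sits, and its true position is unknown beyond that. Compound 2 gives 66100 nM in this assay. Compound 3 gives 5880 nM in this assay, and it is the only one of the three with a firm reading in the lower range.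

Compound 4 `ClCc1ccccc1Cn1cnc2c(Cl)ncnc21` is not yet measured. It differs from compound 1 in one place: hydrogen in place of amino on an aromatic carbon. Within the data shown here, no step of this kind is present among the measured compounds, so the size of the change in this assay cannot be read from them. Given that compound 1 is only a limit, a step in either direction is possible; compound 4 is expected to fall at 30000 nM, with a range of 5000 nM to 150000 nM, which means an expected step of an at least 3.3-fold lower number from compound 1 to compound 4 (0.52 log units; beyond the scatter).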

Compound 4, concentration for total growth inhibition: 5120 nM
Compound 4: middle estimate off by 5.9-fold (0.77 log units), on the high side, within the range that was stated.
By their numbers in this assay, from the lowest: compounds 4 and 3 (each within the scatter of the next); then compound 2. At a limit, above all of these: compound 1.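

In this assay, hydrogen in place of amino on an aromatic carbon, between two ring nitrogen atoms, gives an at least 19-fold lower number from compound 1 to compound 4 (1.29 log units; beyond the scatter). This single pair shows that this position matters in this assay: with hydrogen there, compound 4 gives a firm reading of 5120 nM, whereas the amino group leaves the compound without one. Compound 1 gives > 100000 nM, which is a limit of the assay, so the full size of the step remains unknown: the limit of > 100000 nM in this assay, at which 1 of the 4 values shown sits.

The compounds shown leave open whether a methyl group, a methoxy group or a dimethylamino group at this position would give a reading closer to that of compound 4 or to the limit of compound 1. Going by these compounds, they also rest on one pair, so whether the same change has a similar effect on another core remains open.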